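The compounds below may be only part of what the source reports. "The series", "measured", "known", "first", "only" and "open" are said of these compounds alone.

Measured in an ADME assay on HEK293 cells (Homo sapiens) for inhibition, read by MTT assay, with a stated time of 3 days; on this read-out higher numbers stand for weaker inhibition and lower numbers for stronger inhibition:
- compound 1 `C=CCOc1cc(/C=C\c2cc(OC)c(OC)c(OC)c2)ccc1OC`: 43500 nM
- compound 2 `COc1ccc(/C=C\c2cc(OC)c(OC)c(OC)c2)cc1OCc1ccccc1`: 15000 nM
- compound 3 `COc1ccc(/C=C/CCCOc2cc(/C=C\c3cc(OC)c(OC)c(OC)c3)ccc2OC)cc1`: 88000 nM

Of these three, compound 3 has the highest number, 88000 nM. The next compound in turn is compound 4 `COCOc1cccc(/C=C/CCCOc2cc(/C=C\c3cc(OC)c(OC)c(OC)c3)ccc2OC)c1`, which has not yet been measured. It carries 3-(methoxymethoxy)phenyl in place of 4-methoxyphenyl on a double-bonded chain carbon bound to a double-bonded chain carbon.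

The measured steps bear on this only loosely. They show a 2.0-fold higher number from compound 1 to compound 3 (0.31 log units; beyond the scatter) and a 5.9-fold higher number from compound 2 to compound 3 (0.77 log units; beyond the scatter), as well as a 2.9-fold lower number from compound 1 to compound 2 (0.46 log units; beyond the scatter). Each exchanges the whole group on a saturated chain carbon bound to an oxygen on an aromatic ring, and none swaps one substituted phenyl for another. Among the measured compounds shown here, the data therefore offer no direct precedent and no firm direction, so only a small change is expected. The expected step is a 1.1-fold lower number from compound 3 to compound 4 (0.04 log units; within the scatter). For compound 4 the estimated value is 80000 nM, within an expected range of 30000 nM to 200000 nM.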

Compound 4, half-maximal inhibitory concentration: 30000 nM
Estimate against measurement, compound 4: 2.7-fold (0.43 log units) above; the range from low to high includes it.
By their numbers in this assay, from the lowest: compounds 2, 4 and 1 (each within the scatter of the next, the first and the last beyond it); then compound 3.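

In this assay, the exchange of 4-methoxyphenyl for 3-(methoxymethoxy)phenyl gives a 2.9-fold lower number from compound 3 to compound 4 (0.47 log units; beyond the scatter), toward stronger inhibition. The earlier steps shown here exchanged the whole group on a saturated chain carbon bound to an oxygen on an aromatic ring, whereas this one shows that the number also responds to a change at the far end of the chain, with the rest of compound 3 left intact. The data shown offer no measured explanation for this step.

As far as these compounds go, the step changes both the place of the substituent on the phenyl ring and the substituent itself, so the share of each remains open. Also open, from the compounds shown here alone, is how this position would respond to a plain phenyl, or to a hydroxyl or an amine in place of the methoxymethoxy group.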